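The source may report more compounds than this note shows. Statements on the series, on what has been measured and on what is new or still open speak of the compounds shown alone.

Among the measured compounds shown here, compound 2 `CNc1ncc2c(-c3ccc(N4CCNCC4)nc3)nn(Cc3cn(Cc4ccccc4)nn3)c2n1` gives 2300 nM in an assay for inhibition of tyrosine-protein kinase Mer (Homo sapiens), read by 33P incorporation, in the presence of a further agent that is not named here (a lower number here means a stronger inhibitor, a higher number a weaker inhibitor), the higher of the two numbers measured so far; compound 1 `CNc1ncc2c(-c3ccc(N4CCNCC4)nc3)nn(CC3CCCC3)c2n1` gives 640 nM, and the step of a 3.6-fold higher number from compound 1 to compound 2 (0.56 log units; beyond the scatter) concerns a different part of the molecule. Compound 3 `CNc1ncc2c(-c3ccc(N4CCN(C)CC4)nc3)nn(Cc3cn(Cc4ccccc4)nn3)c2n1` differs from compound 2 by methyl in place of hydrogen on an amine nitrogen in a ring. For the measured compounds named here, no measured step touches this amine nitrogen, so nothing in the data points in either direction, and the step of no change at the digits printed from compound 2 to compound 3 (within the scatter) is expected to stay within the usual scatter. Compound 3 is therefore estimated at 2300 nM, with a range from 800 nM to 6500 nM.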

Compound 3, half-maximal inhibitory concentration: 2000 nM
Compound 3: middle estimate off by 1.2-fold (0.06 log units), on the high side; the measured number falls inside the stated range.
By their numbers in this assay, from the lowest: compound 1; then compounds 3 and 2 (each within the scatter of the next).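

In this assay, among the compounds shown here, methyl in place of hydrogen on the amine nitrogen in the ring gives a 1.2-fold lower number from compound 2 to compound 3 (0.06 log units; within the scatter), the first measured step at this position. With the 1-benzyl-1H-1,2,3-triazol-4-yl group in place, piperazin-1-yl and 4-methylpiperazin-1-yl therefore cannot be told apart in this assay. No available measurement bears on why these two compounds read alike.

On these data alone, whether a larger group on this nitrogen, such as 2-hydroxyethyl or acetyl, would also leave the number within the scatter remains open. So does whether methyl behaves the same way with the cyclopentyl group of compound 1.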